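A few compounds are considered here, and "the series" means these few. Any claim that something is new, unique, unknown or untested is made for them only; others in the source may bear on it.

a functional assay on SGC-7901 cells (Homo sapiens) for antiproliferative activity, read by sulforhodamine B assay, with a stated time of 72 h (a lower number here means a stronger inhibitor, a higher number a weaker inhibitor), gives compound 3 (`CC(=O)Oc1cc2c(CCC=C(C)C)c(C)ccc2cc1C(C)C`) a value of 34400 nM and this is the only true number in the series so far. Compound 1 (`Cc1ccc(/C=C(\C(=O)O)C(C)C)c2c1CC[C@@H](C(C)(C)O)OC2=O`) reads > 100000 nM (a limit of the assay, not a number). Compound 2 (`Cc1ccc(/C=C(\C(=O)O)C(C)C)c2c1CC[C@H](C(C)(C)O)OC2=O`) reads > 100000 nM (again a limit).

The next compound is compound 4 (`CC(=O)Oc1cc2c(CC[C@H](O)C(C)(C)O)c(C)ccc2cc1C(C)C`), reached through 1,2-dihydroxy-2-methylpropyl in place of 2-methylprop-1-en-1-yl on a saturated chain carbon, two bonds along the chain from an aromatic carbon. Among the measured compounds shown here, no measured step covers this change. For the measured compounds named here, the one step available, a step that the two limits leave unreadable from compound 1 to compound 2 (a limit at both ends, so no size can be read), concerns the fact that compounds 1 and 2 differ only in the configuration as drawn and offers no guide here.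

The only further pointer is weak: the limit of > 100000 nM in this assay, at which 2 of the 3 values shown sit (compounds 1 and 2 carry a hydroxyl group, but on a different core and with a carboxylic acid as well). Going by the values given here, on that basis, and starting from compound 3 at 34400 nM (the sole number), the expected change is a 2.3-fold higher number from compound 3 to compound 4 (0.37 log units; beyond the scatter) (estimated toward weaker inhibition, with low confidence). A reading reported only as a limit would be no surprise. The estimate for compound 4 is 80000 nM (expected range 30000 nM to 100000 nM).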

Compound 4, half-maximal inhibitory concentration: 45800 nM
For compound 4 the middle estimate is 1.7-fold (0.24 log units) above the measured one; the range from low to high includes it.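

Among the compounds shown here, replacing 2-methylprop-1-en-1-yl with 1,2-dihydroxy-2-methylpropyl, on a saturated chain carbon, two bonds along the chain from an aromatic carbon, gives the first readable step in this assay: a 1.3-fold higher number from compound 3 to compound 4 (0.12 log units; within the scatter). For the compounds shown here, the earlier compounds gave one number and two limits, and the configuration step between compound 1 and compound 2 cannot be read, so this is the first sign that the reading at this place can hold through a change of this kind: the entering group adds oxygen, hydrogen-bond donors and acceptors and a defined stereocentre, and compound 4 still gives a true number rather than a limit. Nothing on hand bears on why the reading holds through this change.

Still open is whether the defined stereocentre of the 1,2-dihydroxy-2-methylpropyl group matters, since only one configuration of it appears among the compounds shown on this core. Equally open, going by these compounds, is how the reading would respond at this place to an amine, a carboxylic acid or a longer chain, and whether the tolerance seen with compound 4 extends to any of these.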